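Methylsulfonyl in place of (morpholin-4-yl)carbonyl: working notes

This account rests on a few compounds, and the source may have more. Where it says the series, first, only, none or still open, it means among the compounds named here.

Measured in a functional assay on HT-29 cells (Homo sapiens); on this read-out lower numbers stand for an effect already at smaller amounts and higher numbers for an effect only at larger amounts of compound:
- compound 1 `CNC(=O)c1ccc(-c2cc(C(=O)N[C@H]3CCCNC3)c(NC(N)=O)s2)cc1` gives 4300 nM
- compound 2 `NC(=O)Nc1sc(-c2ccc(C(=O)N3CCOCC3)cc2)cc1C(=O)N[C@H]1CCCNC1` gives 610 nM

Of these two numbers, compound 2 holds the lower one (610 nM). Next comes compound 3 `CS(=O)(=O)c1ccc(-c2cc(C(=O)N[C@H]3CCCNC3)c(NC(N)=O)s2)cc1`, with methylsulfonyl in place of (morpholin-4-yl)carbonyl on an aromatic carbon in the comparison with compound 2. Going by the values given here, one measured step bears on this, and only indirectly: a 7.0-fold lower number from compound 1 to compound 2 (0.85 log units; beyond the scatter) on a carbonyl carbon. Among the compounds with values here, compound 3 gives up that carbonyl and the morpholin-4-yl together, and no measured compound carries methylsulfonyl. A modest move to a higher number in this assay is therefore expected, of similar or smaller size than the step to compound 2 from compound 1. The expected step is a 2.5-fold higher number from compound 2 to compound 3 (0.39 log units; beyond the scatter) and remains a rough estimate. Compound 3 is expected at 1500 nM (range 500 nM to 4500 nM) in this estimate.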

Compound 3, half-maximal effective concentration: 200 nM
Compound 3: the middle estimate sits 7.5-fold (0.88 log units) above what was measured; measured number below the stated range.
By their numbers in this assay, from the lowest: compound 3; then compound 2; then compound 1.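

On the aromatic carbon para to a large group, neither a carbonyl nor a ring is needed for the lowest number of the three in this assay: methylsulfonyl gives a 3.1-fold lower number from compound 2 to compound 3 (0.48 log units; beyond the scatter), and set against methylcarbamoyl it gives a 22-fold lower number from compound 1 to compound 3 (1.33 log units; beyond the scatter). Methylsulfonyl and (morpholin-4-yl)carbonyl have the same count of hydrogen-bond acceptors and no donors, so that count does not separate compound 2 from compound 3, although the entering group has fewer heavy atoms. Nothing at hand explains why the sulfone-bearing compound gives the lower number.

Still open, from the compounds shown here alone, is whether ethylsulfonyl, with a longer chain on the sulfur, or a sulfonamide would keep the number this low. A nitrile or a carboxylic acid on the same carbon would show whether the sulfonyl itself matters.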